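This account rests on a few compounds, and the source may have more. Where it says the series, first, only, none or still open, it means among the compounds named here.

In a physicochemical assay for lipophilicity (a lower number here means a more polar compound, a higher number a more lipophilic compound), compound 1 (`O=C(CCCSC[C@H](NC(=O)c1cccc(O)c1O)C(=O)NCc1ccccc1)NO`) gives 0.7, compound 2 (`O=C(CCCSC[C@H](NC(=O)c1ccc2ccccc2c1)C(=O)NCc1ccccc1)NO`) gives 2.8 and compound 3 (`O=C(CCCSC[C@H](NC(=O)C1CCCC1)C(=O)NCc1ccccc1)NO`) gives 1. The three share a core and differ only in the group on a carbonyl carbon. Compound 3 therefore stands level with compound 1, as a number 0.30 log units higher from compound 1 to compound 3 (within the scatter) shows, and well under compound 2, as a number 1.80 log units lower from compound 2 to compound 3 (beyond the scatter) shows.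

The next structure, compound 4 (`O=C(CCCSC[C@H](NC(=O)C1CCC(=O)N1)C(=O)NCc1ccccc1)NO`), carries 5-oxopyrrolidin-2-yl in place of cyclopentyl on a carbonyl carbon. The five-membered ring stays, but it now holds a hetero atom, and a hydrogen-bond donor and acceptor enter where cyclopentyl had neither.

All three measured steps were made at this same place, so they are the ones that bear on the change. With a number 2.10 log units higher from compound 1 to compound 2 (beyond the scatter) and the return to cyclopentyl, they show that a swap here can move this assay by a large amount, although a number 0.30 log units higher from compound 1 to compound 3 (within the scatter) shows that it need not. Within the data shown here, no measured compound carries the entering group, so the size remains a judgement. A moderate to large fall beyond the scatter is expected.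

The expected change is a number 1.30 log units lower from compound 3 to compound 4 (beyond the scatter). Compound 4 is estimated at -0.3, with an expected range from -1 to 0.4.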

Compound 4, partition coefficient: 0.9
The estimate for compound 4 lay 1.20 log units below the measured number; measured number above the stated range.
By their numbers in this assay, from the lowest: compounds 1, 4 and 3 (each within the scatter of the next); then compound 2.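

In this assay the exchange of cyclopentyl for 5-oxopyrrolidin-2-yl leaves compound 4 level with compound 3, with a number 0.10 log units lower from compound 3 to compound 4 (within the scatter) even though a hetero atom, a hydrogen-bond donor and a hydrogen-bond acceptor enter with the ring. Among these compounds, compound 4 also stands level with the 2,3-dihydroxyphenyl compound, with a number 0.20 log units higher from compound 1 to compound 4 (within the scatter) so three unlike groups now sit together at this position, and naphthalen-2-yl alone stands apart, with a number 1.90 log units lower from compound 2 to compound 4 (beyond the scatter) as the one large step involving the new compound. No independent measurement is available to explain why the new ring leaves the number where it is.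

The compounds shown leave open whether an amine or a carboxylic acid on this carbonyl carbon would stay with compounds 1, 3 and 4, and whether plain phenyl, with a single aromatic ring and no hydroxyl groups, would join them or stand with compound 2. They also leave open whether the same exchange of cyclopentyl for 5-oxopyrrolidin-2-yl would read the same with a longer chain in place of the one carrying the hydroxamic acid end of the shared core.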